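Vero tolerance notes: pyridyl to isopropylphenyl swap

The compounds below may be only part of what the source reports. "The series", "measured", "known", "first", "only" and "open" are said of these compounds alone.

Compound 1 `CC1(c2ccc(NC(c3ccncc3)c3nnnn3C(C)(C)C)cc2)NC(=O)c2ccccc2N1` is recorded as "not determined" (no result reported) in an ADME assay on Vero cells (Chlorocebus sabaeus) for cytotoxicity, read by MTT assay, with a stated time of 72 h (a higher number here means that more compound is tolerated, a lower number that less compound is tolerated), so it stands nowhere on the scale yet. Compound 2 `COc1ccc(-c2cc(-c3ccc(C4NC(=O)c5ccccc5N4)cc3)nc(N)n2)cc1`, which shares the core, gives 124000 nM in this assay, a comfortably tolerated level. Compound 3 `CC(C)c1ccc(C(Nc2ccc(C3(C)NC(=O)c4ccccc4N3)cc2)c2nnnn2C(C)(C)C)cc1` differs from compound 1 by 4-isopropylphenyl in place of pyridin-4-yl on a saturated chain carbon bound to an aromatic carbon and a nitrogen on an aromatic ring. For the measured compounds named here, with no measured pair to anchor the step, the expectation for this assay is a modest loss of tolerance, most likely within or only slightly beyond the usual scatter, rather than a large shift. Compound 3 is therefore estimated at 60000 nM, with a plausible range from 15000 nM to 200000 nM.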

Compound 3, half-maximal cytotoxic concentration: > 400000 nM
Compound 3 gave a limit, no number; the forecaster's own chance of this, stated with the estimate: 40%; at least 6.6-fold (0.82 log units) between middle value and limit.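

No step can be read from compound 1 to compound 3: compound 1 has no single number, and compound 3 gives only a limit. The compounds shown leave open what replacing pyridin-4-yl with 4-isopropylphenyl does to tolerance.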